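The compounds below may be only part of what the source reports. "The series", "measured", "known", "first", "only" and "open" are said of these compounds alone.

Measured compounds in an ADME assay (Mus musculus, strain C57BL/6) for metabolic stability, read by HPLC, with a stated time of 12 h; on this read-out lower numbers stand for a shorter-lived compound and higher numbers for a longer-lived compound:
Compound 1 `O=C(O)[C@@H](CO)NC(=O)[C@H]1C[C@@H](O)CN1`: > 12 h
Compound 2 `O=C(O)[C@@H](CO)NC(=O)[C@H]1C[C@H](O)CN1`: > 12 h
Compound 3 `O=C(N[C@H](CO)C(=O)O)[C@@H]1C[C@H](O)CN1`: > 12 h

Each of these entries is a limit and not a number. Compound 3 therefore has no exact position in this assay, and the three compounds share (the limit of > 12 h in this assay, at which 3 of the 3 values shown sit).

Compound 4 `O=C(O)[C@H](CO)NC(=O)[C@@H]1C[C@H](O)CN1` has not yet been measured. It departs from compound 3 by the two compounds have the same atoms and bonds and differ only in configuration as drawn: 1 of 3 stereo elements differ; a stereocentre at a saturated chain carbon is drawn R in compound 3 and S in compound 4: nothing leaves and nothing enters, and the change lies at a saturated chain carbon.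

Within the data shown here, three measured steps bear on this only loosely: a step that the two limits leave unreadable from compound 1 to compound 2, a step that the two limits leave unreadable from compound 2 to compound 3 and a step that the two limits leave unreadable from compound 1 to compound 3. Among the measured compounds shown here, none has a readable size, and each concerns saturated ring carbons, so no measured step changes the chain carbon. The expectation rests on compound 3, with its limit of > 12 h. No step beyond the scatter is expected, and no direction can be argued.

The expected step is a step that the limit leaves unreadable from compound 3 to compound 4.

For compound 4 the estimate is 14 h, with an expected range from 7 h to 28 h.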

Compound 4, half-life: 1.15 h
Compound 4: middle estimate off by 12-fold (1.09 log units), on the high side; measured number below the stated range.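

Drawing the saturated chain carbon S rather than R gives an at least 10-fold lower number from compound 3 to compound 4 (1.01 log units; beyond the scatter) in this assay, and this can be put down to configuration alone because nothing else changes: the fact that compounds 3 and 4 differ only in the configuration as drawn

Two further steps can be read, an at least 10-fold lower number from compound 2 to compound 4 (1.01 log units; beyond the scatter) and an at least 10-fold lower number from compound 1 to compound 4 (1.01 log units; beyond the scatter), but these pairs also differ at saturated ring carbons, and compound 4 is the mirror image of compound 1. The steps among compounds 1, 2 and 3 cannot be read, since each of those compounds stands at a limit, so only the chain carbon has shown a readable effect.

Going by these compounds, whether the ring carbons matter when the chain carbon is drawn S remains open. So does whether the same inversion would lower the number as far with a primary amide in place of the carboxylic acid.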